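Nitro for methyl on a sulfonyl aryl: a small series

The source may hold more compounds than are shown below. What is called first, only, known or untested is meant among the compounds shown, and "the series" means these compounds.

Three compounds were measured in a functional assay for inhibition, read by spectrophotometry, with a stated time of 20 min, tested at 3 mg/mL; on this read-out lower numbers stand for a weaker effect and higher numbers for a stronger effect at the one concentration tested. Compound 1 `CC(=O)c1ccc(NC(=O)CN(C(=O)c2ccccc2)S(=O)(=O)c2ccc(C)cc2)cc1` gives 18.2%. Compound 2 `CC(=O)c1ccc(NC(=O)C2CC(O)CN2S(=O)(=O)c2ccc(C)cc2)cc1` gives 12.7%, the lowest of the three numbers, though its gap to compound 1 lies within the scatter, so no order between the two can be claimed. Compound 3 `CCC(C)C(C(=O)Nc1ccc(C(C)=O)cc1)N(C(=O)c1ccccc1)S(=O)(=O)c1ccc([N+](=O)[O-])cc1` gives 42.1%, which stands beyond the scatter above compound 2; compound 3 differs from compound 2 in several places at once, so its higher value cannot be tied to any one change.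

Compound 4 `CC(=O)c1ccc(NC(=O)C2CC(O)CN2S(=O)(=O)c2ccc([N+](=O)[O-])cc2)cc1` has not yet been measured. It differs from compound 2 by nitro in place of methyl on an aromatic carbon, that is, 4-methylphenyl becomes 4-nitrophenyl on the sulfonyl group. Going by the values given here, no pair of measured compounds isolates this change. Among the compounds with values here, compound 3 is the only measured compound bearing a nitro on that ring, but it carries other differences too. On this basis, a modest rise is expected for compound 4, a step of a number 7.3 percentage points higher from compound 2 to compound 4 (within the scatter) in this assay. Compound 4 is therefore estimated at 20%, within a range from 8% to 38%.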

Compound 4, a percentage reported as inhibition, at one concentration (the size of the read-out at that concentration, not a potency): 58.7%
Compound 4: middle estimate off by 38.7 percentage points, on the low side; measured number above the stated range.
By their numbers in this assay, from the lowest: compounds 2 and 1 (each within the scatter of the next); then compound 3; then compound 4.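

In this assay, going by these compounds alone, the change from 4-methylphenyl to 4-nitrophenyl on the sulfonyl group gives a number 46 percentage points higher from compound 2 to compound 4 (beyond the scatter) and this is the first pair to isolate that change. Before this result, a nitro on that ring appeared only in compound 3, where other differences came with it, so nothing could be tied to the nitro alone. With everything else in compound 2 held constant, this position is now shown to be one where a single substituent change moves the read-out well beyond the usual scatter, but no measurement here accounts for the size of the step.

Going by these compounds, whether the same change would give a similar step on the core of compound 1 remains open. So does what an amine or a carboxylic acid in place of the nitro would give at this place on the ring.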